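The compounds below may be only part of what the source reports. "The series", "measured", "known", "first", "only" and "open" are said of these compounds alone.

Compound 3 (`COc1cc(NC(C)CCCNC(=O)NC2CCCC2)c2ncccc2c1`) carries a cyclopentyl group on an amide-type nitrogen, and in an ADME assay on L6 cells (Rattus norvegicus) for cytotoxicity, read by resazurin assay, with a stated time of 70 h (on this read-out higher numbers stand for weaker inhibition and lower numbers for stronger inhibition), compound 3 has "not determined" (no result reported), so no number places it among the others. Compound 1 (`COc1cc(NC(C)CCCNC(=O)/C=C/c2ccccc2)c2ncccc2c1`) gives 18500 nM in this assay. Compound 2 (`COc1cc(NC(C)CCCNC(=O)/C(C)=C/c2ccccc2)c2ncccc2c1`) reaches only a limit of this assay, > 250000 nM, not a number. Going by the values given here, the one measured step, an at least 13-fold higher number from compound 1 to compound 2 (1.13 log units; beyond the scatter), shows how a small change beside the carbonyl can move the read-out, with the limit of > 250000 nM in this assay, at which 1 of the 3 values shown sits, bounding what can be seen. Compound 4 (`COc1cc(NC(C)CCCNC(=O)NNC(=O)/C=C/c2ccccc2)c2ncccc2c1`) arises by ((2-phenylethenyl)carbonyl)amino in place of cyclopentyl on an amide-type nitrogen. Among the compounds with values here, no measured step bears on this change, so compound 3 offers no anchor, and only compound 1, which shares the 2-phenylethenyl carbonyl, hints at weak cytotoxicity. Compound 4 is therefore expected to give about 40000 nM, within 8000 nM to 250000 nM.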

Compound 4, half-maximal inhibitory concentration: 13900 nM
Compound 4: middle estimate off by 2.9-fold (0.46 log units), on the high side; measured number inside the range.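

Going by these compounds alone, no step from compound 3 to compound 4 can be read in this assay. The compounds shown leave open how ((2-phenylethenyl)carbonyl)amino compares with cyclopentyl on an amide-type nitrogen on this read-out.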